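Swapping One Chlorine Atom for a Much Larger Group

A few compounds are considered here, and "the series" means these few. Any claim that something is new, unique, unknown or untested is made for them only; others in the source may bear on it.

Compound 1 (`O=C(CCl)Nc1ccc(C(=O)/C=C/c2cccc(Cl)c2)cc1`) gives 2010 nM in a functional assay on MGC-803 cells (Homo sapiens) for cytotoxicity, read by MTT assay, with a stated time of 72 h (a lower number here means a stronger inhibitor, a higher number a weaker inhibitor), and serves as the reference point here. Compound 2 (`COc1cccc(/C=C/C(=O)c2ccc(NC(=O)CCl)cc2)c1`) gives 2910 nM in the same test, and compound 3 (`Cc1ccc(/C=C/C(=O)c2ccc(NC(=O)CCl)cc2)cc1`) gives 3600 nM there. These results amount to a 1.4-fold higher number from compound 1 to compound 2 (0.16 log units; within the scatter) and a 1.8-fold higher number from compound 1 to compound 3 (0.25 log units; within the scatter) in size, so compound 1 stands level with both and the three cannot be ranked.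

Compound 4 (`O=C(CSC(=S)N[C@H]1CCOC1=O)Nc1ccc(C(=O)/C=C/c2cccc(Cl)c2)cc1`) keeps the core of compound 1 and differs from it in one place (a group of 10 heavy atoms (5 carbon, 1 nitrogen, 2 oxygen, 2 sulfur; one five-membered non-aromatic ring with 1 hetero atom) in place of one chlorine atom, on a saturated chain carbon bound to a carbonyl carbon). Going by the values given here, neither measured step touched that saturated chain carbon, and no measured compound carries the new group, so those two small steps say little about this change. Compound 1 at 2010 nM is therefore the only real anchor, and the data give no direction for so large a swap. A shift beyond the scatter is not firmly expected: the estimated step is a 1.3-fold lower number from compound 1 to compound 4 (0.13 log units; within the scatter) and its direction remains uncertain. For compound 4 the estimate is 1500 nM in this assay with an expected range from 350 nM to 7000 nM to allow for that uncertainty.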

Compound 4, half-maximal inhibitory concentration: 15600 nM
Estimate against measurement, compound 4: 10-fold (1.02 log units) below, outside the stated range (above it).
By their numbers in this assay, from the lowest: compounds 1, 2 and 3 (each within the scatter of the next); then compound 4.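

The saturated chain carbon bound to a carbonyl carbon is a place where a change clearly registers in this assay: putting the group of 10 heavy atoms in place of the chloro gives a 7.8-fold higher number from compound 1 to compound 4 (0.89 log units; beyond the scatter) and so moves the number beyond the scatter, whereas the two earlier steps, made elsewhere in the molecule, both stayed within it. This shows that the core of compound 1 does not keep its number under every change at this carbon, and that this large group, with its five-membered non-aromatic ring and two sulfur atoms, goes with a weaker result. The swap changes many things at once, however, so this single step cannot show which part of the new group matters, and nothing measured here accounts for the shift.

The compounds shown leave open whether a small replacement for the chloro on this carbon, such as an amine or a hydroxyl, would keep the number close to that of compound 1. On these data alone, it also remains open whether a simple sulfur-linked methyl group, without the ring, would shift the number as far as the full group does.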